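The source may report more compounds than this note shows. Statements on the series, on what has been measured and on what is new or still open speak of the compounds shown alone.

Compound 2 `Cc1cc(Nc2cc(-c3ccccc3)[nH]n2)n2nc(SCc3cccc(Br)c3)nc2n1` stands at the upper edge of what has been measured in an ADME assay on GES1 cells (Homo sapiens) for inhibition, read by MTT assay, with a stated time of 72 h; on this read-out higher numbers stand for weaker inhibition and lower numbers for stronger inhibition. Compound 2 gives > 50000 nM, which is a limit of the assay rather than a number. Compound 1 `Cc1cc(Nc2cc(-c3ccccc3)[nH]n2)n2nc(SCCCc3ccccc3)nc2n1` gives 40200 nM in this assay. Compound 3 `CCCCCc1c(C)nc2nc(SCc3ccc(Cl)cc3)nn2c1Nc1cc(-c2ccccc2)[nH]n1` gives > 50000 nM in this assay, again a limit.

Among the measured compounds shown here, the only measured step that alters the group on the saturated chain carbon bound to a sulfur is an at least 1.2-fold higher number from compound 1 to compound 2 (0.09 log units; that floor lies within the scatter), and it ends at the limit of > 50000 nM in this assay, at which 2 of the 3 values shown sit, so its true size is not known beyond its floor. Compound 4 `CCCSc1nc2nc(C)cc(Nc3cc(-c4ccccc4)[nH]n3)n2n1` differs from compound 2 by ethyl in place of 3-bromophenyl on a saturated chain carbon bound to a sulfur. For the measured compounds named here, the one step that bears on this position offers only a floor within the scatter, and both compounds flanking it sit at or near the limit, so no step beyond the scatter is expected in this assay, in either direction. The most likely outcome is that compound 4 also reports only a limit. Compound 4 is therefore estimated at 60000 nM in this assay, within a range from 30000 nM to 150000 nM. The expected step is a step that the limit leaves unreadable from compound 2 to compound 4.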

Compound 4, half-maximal inhibitory concentration: > 50000 nM
Compound 4: no number, only a limit; the forecaster's own chance of this, stated with the estimate: 75%; the middle value lies beyond the limit too.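

In this assay the step from compound 2 to compound 4 cannot be read, because both ends of it are limits and not numbers: the limit of > 50000 nM in this assay, at which 3 of the 4 values shown sit. Even so, compound 4 carries no ring on this chain and reports the same limit as compound 2, so among these two compounds the 3-bromophenyl group is not needed for that limit to be reached. Hydrogen in place of phenyl on a saturated chain carbon, three bonds along the chain from a sulfur, gives an at least 1.2-fold higher number from compound 1 to compound 4 (0.09 log units; that floor lies within the scatter), so this step too offers only a floor and its true size remains unknown.

Compound 1 is the only one of these compounds with a true number, 40200 nM. As far as these compounds go, how far compound 2 and compound 4 lie beyond the limit stays open. From the compounds shown here alone, it also stays open how an amine or a carboxylic acid at the end of this chain, or a longer chain of carbon only, would read in this assay, and whether any of them would give a number rather than a limit.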